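Moving the methyl on the amide-bound phenyl ring

A few compounds are considered here, and "the series" means these few. Any claim that something is new, unique, unknown or untested is made for them only; others in the source may bear on it.

Of the compounds shown here, two have been tested in a functional assay on the whole organism for inhibition, with Rattus norvegicus as the target, read by paw edema, with stated times of 30 min and 3 h, at a dose of 0.28 mmol/kg by the oral route; a lower number here means less inhibition, a higher number more inhibition at the dose given (going by the name of the read-out). Compound 1 `COc1ccc(NC(=O)c2nc(-c3cc(OC)c(OC)c(OC)c3)n(-c3ccc(OC)cc3)n2)cc1` gives 99%. Compound 2 `COc1ccc(-n2nc(C(=O)Nc3ccc(C)cc3)nc2-c2cc(OC)c(OC)c(OC)c2)cc1` gives 88%, the lower of the two numbers, and the step of a number 11 percentage points lower from compound 1 to compound 2 (beyond the scatter) places it beyond the scatter. Compound 3 `COc1ccc(-n2nc(C(=O)Nc3ccccc3C)nc2-c2cc(OC)c(OC)c(OC)c2)cc1` has not yet been measured. It differs from compound 2 in one place: 2-methylphenyl in place of 4-methylphenyl on an amide-type nitrogen. The ring that leaves and the ring that enters carry the same atoms; only the point at which the methyl sits on the ring has moved, with the ring still attached to the amide-type nitrogen next to the carbonyl carbon. Among the measured compounds shown here, no measured step bears directly on this change. For the measured compounds named here, the one step seen, from methoxy to methyl at the same ring, is of a different kind, so it gives only a weak hint of how sensitive the read-out is to this ring. The expected step in this assay is therefore a number 8 percentage points lower from compound 2 to compound 3 (within the scatter), small and uncertain in direction. Compound 3 is estimated at 80%, with a range from 60% to 95%.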

Compound 3, a percentage reported as inhibition, in the whole organism at one dose (the size of the read-out at that dose, not a potency): 74%
For compound 3 the middle estimate is 6 percentage points above the measured one; measured number inside the range.
By their numbers in this assay, from the lowest: compound 3; then compound 2; then compound 1.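

In this assay, shifting only the methyl, with the ring's atoms unchanged, gives a number 14 percentage points lower from compound 2 to compound 3 (beyond the scatter) and shows that the read-out depends on where the methyl sits on the ring attached to the amide-type nitrogen, not just on which group the ring carries. The earlier step changed the group itself, whereas the wider comparison of 2-methylphenyl with 4-methoxyphenyl on this nitrogen gives a number 25 percentage points lower from compound 1 to compound 3 (beyond the scatter) and places both the kind of group and its place on the ring among the changes this read-out can register. Nothing measured here explains why the inhibition falls with this shift.

The compounds shown leave open how a ring carrying an amine or a carboxylic acid in place of the methyl would behave, and whether a longer chain such as ethyl would follow the same course as the methyl. All three numbers also come from a single oral dose, so they describe the size of the effect at that dose and cannot show how the compounds would compare at other doses.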